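Hydroxy addition onto the bromo-bearing side of the core

This account rests on a few compounds, and the source may have more. Where it says the series, first, only, none or still open, it means among the compounds named here.

Compound 2, `O=C(Nc1cccc(Cl)c1)c1cccc(Br)c1`, stands at the bottom of what has been measured in an assay for inhibition of HSP60/HSP10 (Homo sapiens), with a stated time of 60 min; on this read-out higher numbers stand for weaker inhibition and lower numbers for stronger inhibition. In this assay compound 2 gives only a limit, > 100000 nM, and no number. Compound 1, `O=C(Nc1ccccc1)c1cc(Br)ccc1O`, shares the bromo-bearing half of the core and carries the hydroxy group. In this assay compound 1 likewise gives only a limit, > 100000 nM. Together the two show nothing beyond (the limit of > 100000 nM in this assay, at which 2 of the 2 values shown sit), so neither the hydroxy nor the chloro has yet been seen to move the read-out. Compound 3, `O=C(Nc1cccc(Cl)c1)c1cc(Br)ccc1O`, is not yet measured. Compared with compound 2 the change is hydroxy in place of hydrogen on an aromatic carbon. For the measured compounds named here, no measured step tracks that change directly. Compound 1 already holds the hydroxy and gives only the limit > 100000 nM. The step from compound 2 to compound 3 is therefore expected to be none beyond the scatter, with a further limit the likeliest outcome. The estimate for compound 3 is 150000 nM, with a range from 30000 nM to 600000 nM. The estimated step is a step that the limit leaves unreadable from compound 2 to compound 3.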

Compound 3, half-maximal inhibitory concentration: > 100000 nM
Compound 3: no number, only a limit; the forecaster's own chance of this, stated with the estimate: 75%; the middle value does not contradict the limit.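

The steps from compound 1 and from compound 2 to compound 3 cannot be read, because all three compounds give only a limit: the limit of > 100000 nM in this assay, at which 3 of the 3 values shown sit. The compounds shown leave open whether the hydroxy or the chloro changes inhibition at all in this assay, and whether any compound on the shared core gives a number there.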